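The source may hold more compounds than are shown below. What is called first, only, known or untested is meant among the compounds shown, and "the series" means these compounds.

In a functional assay on NCI-H460 cells (Homo sapiens) for cytotoxicity, read by MTT assay, with a stated time of 48 h (a lower number here means a stronger inhibitor, a higher number a weaker inhibitor), the series has yet to yield a number. Compound 1 (`COc1ccc(/C=C/C(=O)/C=C/c2cc3ccccc3nc2Oc2ccccc2)c(OC)c1`) gives > 10000 nM, which is a limit. Compound 2 (`COc1ccc(/C=C/C(=O)/C=C/c2cc3ccccc3nc2Oc2ccccc2)cc1OC`) gives > 10000 nM, also a limit. Compound 3 (`COc1cc(OC)c(/C=C/C(=O)/C=C/c2cc3ccccc3nc2Oc2ccccc2)c(OC)c1`) gives > 10000 nM, again a limit. Compound 3 therefore has no number of its own and stands with the others at the limit of > 10000 nM in this assay, at which 3 of the 3 values shown sit.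

Compound 4 (`COc1cc(OC)c(/C=C/C(=O)/C=C/c2cc3ccccc3nc2Oc2ccc(Br)cc2)c(OC)c1`) carries bromo in place of hydrogen on an aromatic carbon, turning phenoxy to 4-bromophenoxy: bromo in place of hydrogen on an aromatic carbon.

Going by the values given here, two measured steps bear on this only loosely: a step that the two limits leave unreadable from compound 1 to compound 2 and a step that the two limits leave unreadable from compound 1 to compound 3. Neither has a readable size, and neither alters the phenoxy group, so no size or direction carries over to the new change. The expectation rests on compound 3 at the limit of > 10000 nM in this assay, at which 3 of the 3 values shown sit, and a reading again at the limit is the likeliest outcome.

The estimated change is an at least 1.2-fold lower number from compound 3 to compound 4 (0.09 log units; that floor lies within the scatter), with its direction uncertain. For compound 4 the expected value is 8000 nM, with an estimated range of 1500 nM to 20000 nM.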

Compound 4, half-maximal inhibitory concentration: > 10000 nM
Compound 4 was reported as a limit; the forecaster's own chance of this, stated with the estimate: 55%; middle value at least 1.2-fold (0.09 log units) away from the limit.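

In this assay compound 3 and compound 4 both stand at a limit, so no size can be read for the bromo change between them: the limit of > 10000 nM in this assay, at which 4 of the 4 values shown sit. The compounds shown leave open whether any change in this series yields a measured number, and in which direction bromo acts.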